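Methoxy on the hydroxyphenyl arm: outlook for compound 3

The compounds below may be only part of what the source reports. "The series", "measured", "known", "first", "only" and "open" are said of these compounds alone.

Among the compounds with values here, compound 2 `CN(C)CCn1cnnc1-c1cc(Oc2ccc(NC(=O)N/N=C/c3ccc(O)cc3)cc2F)ccn1` gives 7750 nM in a functional assay on U-87MG ATCC cells (Homo sapiens) for cytotoxicity, read by MTT assay, with a stated time of 72 h (on this read-out lower numbers stand for stronger inhibition and higher numbers for weaker inhibition), the highest of the two numbers so far; compound 1 `CN(C)CCn1cnnc1-c1cc(Oc2ccc(NC(=O)N/N=C/c3c[nH]c4ccccc34)cc2F)ccn1` gives 690 nM, and the step of an 11-fold higher number from compound 1 to compound 2 (1.05 log units; beyond the scatter) marks that gap. Compound 3 `COc1cc(/C=N/NC(=O)Nc2ccc(Oc3ccnc(-c4nncn4CCN(C)C)c3)c(F)c2)ccc1O` differs from compound 2 by methoxy in place of hydrogen on an aromatic carbon. Within the data shown here, the single measured step exchanges the whole ring for another and does not bear on a methoxy placed ortho to a hydroxy group, so no guide exists for this change. A step within the scatter is therefore expected, a 1.1-fold lower number from compound 2 to compound 3 (0.04 log units; within the scatter). Compound 3 is estimated at 7000 nM, with a range from 3000 nM to 16000 nM.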

Compound 3, half-maximal inhibitory concentration: > 100000 nM
Compound 3: a limit, no number; the forecaster's own chance of this, stated with the estimate: 5%; at least 14-fold (1.15 log units) between middle value and limit.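

Compound 3 carries a limit, not a number, in this assay: the limit of > 100000 nM in this assay, at which 1 of the 3 values shown sits. On the 4-hydroxyphenyl arm, a methoxy ortho to a hydroxy group is the only change shown that leaves the ring in place, and this one addition already gives an at least 12-fold higher number from compound 2 to compound 3 (1.11 log units; beyond the scatter). The gap to the 1H-indol-3-yl arm widens to an at least 140-fold higher number from compound 1 to compound 3 (2.16 log units; beyond the scatter).

Going by these compounds, whether this holds for any group at this carbon or for methoxy alone stays open; a methyl, a chlorine or an ethoxy there would separate the two. Also open, on these data alone, is how the hydroxy group contributes, which a methoxy on a ring without it would address.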